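A few compounds are considered here, and "the series" means these few. Any claim that something is new, unique, unknown or untested is made for them only; others in the source may bear on it.

Working notes on the series. Among the compounds with values here, compound 1 `O=c1ccoc2cc(OCc3cn(Cc4ccccc4)nn3)ccc12` is the reference point; in a functional assay on SW480 cells (Homo sapiens) for cytotoxicity, read by MTT assay, with a stated time of 48 h (on this read-out lower numbers stand for stronger inhibition and higher numbers for weaker inhibition), compound 1 gives 42900 nM, the highest of the three numbers measured so far. Compound 2 `O=c1ccoc2cc(OCc3cn(Cc4cccc(Cl)c4)nn3)ccc12` gives 12900 nM and compound 3 `O=c1ccoc2cc(OCc3cn(Cc4ccccc4F)nn3)ccc12` gives 11400 nM. Both substituted analogues move in the same direction: a 3.3-fold lower number from compound 1 to compound 2 (0.52 log units; beyond the scatter), and a 3.8-fold lower number from compound 1 to compound 3 (0.58 log units; beyond the scatter). Between the two substituted compounds the difference is small, a 1.1-fold lower number from compound 2 to compound 3 (0.05 log units; within the scatter), so chloro and fluoro entering on the aromatic carbon come out much the same.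

Compound 4 `O=c1ccoc2cc(OCc3cn(Cc4ccccc4Br)nn3)ccc12` is not yet measured. Relative to compound 1 the change is bromo in place of hydrogen on an aromatic carbon; cut one bond further out it reads benzyl to 2-bromobenzyl, the bromo sitting ortho to a large group, the same position that carries fluoro in compound 3. Within the data shown here, the steps that bear on this are the two from compound 1, each a modest lowering of the number well beyond the scatter, with no sign that the choice of group or position between chloro and fluoro matters. A similar modest step downward is therefore expected for bromo. Compound 4 is expected to give about 12000 nM, within roughly 5000 nM to 30000 nM. This amounts to an expected step of a 3.6-fold lower number from compound 1 to compound 4 (0.55 log units; beyond the scatter).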

Compound 4, half-maximal inhibitory concentration: > 100000 nM
Compound 4 gave a limit, no number (the forecaster's own chance of this, stated with the estimate: 3%); at least 8.3-fold (0.92 log units) between middle value and limit.
By their numbers in this assay, from the lowest: compounds 3 and 2 (each within the scatter of the next); then compound 1. At a limit, above all of these: compound 4.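

In this assay compound 4 stands at a limit and not at a number: the limit of > 100000 nM in this assay, at which 1 of the 4 values shown sits. Adding a bromo on the aromatic carbon, ortho to a large group, moves the read-out in the opposite direction to chloro and fluoro, with an at least 2.3-fold higher number from compound 1 to compound 4 (0.36 log units; beyond the scatter), so the agreement between compound 2 and compound 3 does not extend to every halogen in this series. The sharpest comparison is the change of fluoro to bromo with the place held fixed, which gives an at least 8.7-fold higher number from compound 3 to compound 4 (0.94 log units; beyond the scatter), while an at least 7.7-fold higher number from compound 2 to compound 4 (0.88 log units; beyond the scatter) changes both the halogen and its place on the ring and so cannot separate the two.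

Left open is whether chloro in that same place, ortho to a large group, reads with fluoro or with bromo, and how far the true value of compound 4 lies past its limit. Also open, from the compounds shown here alone, is how a methoxy group or an amine on that aromatic carbon would read.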